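The source may report more compounds than this note shows. Statements on the series, on what has been measured and on what is new or still open speak of the compounds shown alone.

For the measured compounds named here, in a functional assay on KB 3-1 cells (Homo sapiens) for antiproliferative activity, read by MTT assay, with a stated time of 72 h (on this read-out higher numbers stand for weaker inhibition of growth and lower numbers for stronger inhibition of growth), compound 1 `Cc1c(C(=O)Nc2ccc(SC#N)cc2)nnn1-c1ccc(C(C)C)cc1` gives 7400 nM and compound 2 `Cc1ccc(-n2nnc(C(=O)Nc3ccc(SC#N)cc3)c2C)cc1C` gives 61000 nM as the higher of the two numbers so far. Compound 3 `Cc1ccc(Cl)cc1-n1nnc(C(=O)Nc2ccc(SC#N)cc2)c1C` is not yet measured. It differs from compound 2 by 5-chloro-2-methylphenyl in place of 3,4-dimethylphenyl on an aromatic nitrogen with 5-chloro-2-methylphenyl in place of 3,4-dimethylphenyl on an aromatic nitrogen. Going by the values given here, the one measured step at this place is an 8.2-fold higher number from compound 1 to compound 2 (0.92 log units; beyond the scatter) and it is modest but beyond the scatter. Among the compounds with values here, that single step shows the number can move with this group, but 5-chloro-2-methylphenyl appears in no measured compound, so the direction is poorly set. Compound 2 at 61000 nM sits at the high end of a very short series, so a smaller step toward a lower number is expected. The expected change is a 2.4-fold lower number from compound 2 to compound 3 (0.39 log units; beyond the scatter) and the opposite direction cannot be excluded. For compound 3 the estimated value is 25000 nM with an expected range of 6000 nM to 100000 nM around it.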

Compound 3, concentration for 50% growth inhibition: 7800 nM
Compound 3: middle estimate off by 3.2-fold (0.51 log units), on the high side; the measured number falls inside the stated range.
By their numbers in this assay, from the lowest: compounds 1 and 3 (each within the scatter of the next); then compound 2.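

In this assay, for the compounds shown here, the change to 5-chloro-2-methylphenyl gives a 7.8-fold lower number from compound 2 to compound 3 (0.89 log units; beyond the scatter) and so sets a direction for this pair of groups that the single earlier step could not, with the size of the move coming from a swap of two substituted phenyl groups of equal heavy-atom count. Compound 3 against compound 1 gives a 1.1-fold higher number from compound 1 to compound 3 (0.02 log units; within the scatter) and so does not separate 5-chloro-2-methylphenyl from 4-isopropylphenyl, which leaves compound 2 as the only one of the three apart from the others. Nothing available explains the difference between these groups at this position.

The swap changes the substituents on the phenyl ring together, so the separate share of the chlorine and of the methyl group remains unresolved. As far as these compounds go, how 2-methylphenyl, 3-chlorophenyl or an unsubstituted phenyl would compare on the same core also remains open.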